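Cyclopentyl in Place of Cyclohexylmethyl on the Ether Oxygen

A few compounds are considered here, and "the series" means these few. Any claim that something is new, unique, unknown or untested is made for them only; others in the source may bear on it.

Measured so far in an assay on SK-BR-3 cells for inhibition of Aromatase (Homo sapiens); a lower number here means a stronger inhibitor, a higher number a weaker inhibitor:
- compound 1, `CC(C)Oc1cc([N+](=O)[O-])ccc1NS(C)(=O)=O`, gives 5870 nM
- compound 2, `CS(=O)(=O)Nc1ccc([N+](=O)[O-])cc1OCC1CCCCC1`, gives 1210 nM

Going by the values given here, of these two numbers compound 2 holds the lower one; its only neighbour is compound 1, and the single measured step, a 4.9-fold lower number from compound 1 to compound 2 (0.69 log units; beyond the scatter), separates them. Compound 3, `CS(=O)(=O)Nc1ccc([N+](=O)[O-])cc1OC1CCCC1`, has not yet been measured. It differs from compound 2 in one place: cyclopentyl in place of cyclohexylmethyl on an oxygen on an aromatic ring.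

Among the compounds with values here, the only step that bears on this change is a 4.9-fold lower number from compound 1 to compound 2 (0.69 log units; beyond the scatter), which went from a short open-chain group to a larger ring-bearing one on the same oxygen and gave a modest drop in this assay. The move to cyclopentyl goes part of the way back toward compound 1, so a modest rise beyond the scatter is expected, smaller than that step. Compound 3 is therefore estimated at 2500 nM, within 1000 nM to 7000 nM, an expected step of a 2.1-fold higher number from compound 2 to compound 3 (0.32 log units; beyond the scatter).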

Compound 3, half-maximal inhibitory concentration: 870 nM
Beside the measured number, compound 3's estimate is 2.9-fold (0.46 log units) above it; measured number outside the range, below it.
By their numbers in this assay, from the lowest: compounds 3 and 2 (each within the scatter of the next); then compound 1.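

In this assay, the step to compound 3 (a 1.4-fold lower number from compound 2 to compound 3 (0.14 log units; within the scatter)) shows that this position on the oxygen accepts a change from cyclohexylmethyl, with 7 heavy atoms, to cyclopentyl, with 5, with no difference that can be told from scatter. The second step (a 6.7-fold lower number from compound 1 to compound 3 (0.83 log units; beyond the scatter)) gives a second ring-bearing group that separates from isopropyl, so across these compounds both groups with a carbon ring give lower numbers than the open-chain group, and none goes against this. No measurement here accounts for these differences.

The compounds shown leave open whether the ring itself matters or whether an open chain of similar size, such as a longer pentyl chain, would do the same. They also leave open how this position responds to a group carrying an amine or a carboxylic acid.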